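Chain extension on the amino side chain: compound 2 to compound 4

The compounds below may be only part of what the source reports. "The series", "measured", "known", "first", "only" and "open" are said of these compounds alone.

Compound 2 `CCCN(CCC)c1nc(C)nc2c(-c3ccc(OC)nc3C)c(C)nn12` gives 5.7 nM in an assay on cell membranes for displacement of a labelled ligand from corticotropin-releasing factor receptor 1 (Rattus norvegicus) (a lower number here means a stronger inhibitor, a higher number a weaker inhibitor), the lowest number of the three measured compounds. Compound 3 `CCCCN(CCC)c1nc(C)nc2c(-c3c(C)cc(N(C)C)nc3C)c(C)nn12` gives 12.8 nM, and compound 1 `CCC(CC)Nc1nc(C)nc2c(-c3c(C)cc(N(C)C)nc3C)c(C)nn12` gives 25.6 nM. Among the compounds with values here, the only step measured on this side chain, a 2.0-fold lower number from compound 1 to compound 3 (0.30 log units; within the scatter), concerns a different exchange on the other aryl series. Compound 4 `CCCCN(CCC)c1nc(C)nc2c(-c3ccc(OC)nc3C)c(C)nn12` differs from compound 2 by methyl in place of hydrogen on a saturated chain carbon, three bonds along the chain from a nitrogen on an aromatic ring. Within the data shown here, no measured pair shows this exact change, so the estimate rests on compound 3, whose butyl(propyl)amino group gives 12.8 nM on the other aryl. For compound 4 the expected step is a 1.0-fold lower number from compound 2 to compound 4 (0.02 log units; within the scatter), no change beyond the scatter. Compound 4 is thus estimated at 5.5 nM, between 2.5 nM and 12 nM.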

Compound 4, half-maximal inhibitory concentration: 2.4 nM
Estimate against measurement, compound 4: 2.3-fold (0.36 log units) above; measured number below the stated range.
By their numbers in this assay, from the lowest: compound 4; then compound 2; then compounds 3 and 1 (each within the scatter of the next).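

In this assay the propyl to butyl change, with the aryl group of compound 2 held fixed, gives a 2.4-fold lower number from compound 2 to compound 4 (0.38 log units; beyond the scatter) as a modest step. Within the data shown here, this is the first step on the amino side chain that lies beyond the scatter, and it shows that this saturated chain carbon accepts a methyl with a lower number. No evidence on the cause of this step is available. 

On these data alone, whether a longer chain such as pentyl lowers the number further remains open. Also open, as far as these compounds go, is whether the same extension on the other propyl group, giving dibutylamino, has a similar effect.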